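Ring methyl removal in pyridyl amidrazone thiosemicarbazides

The source may hold more compounds than are shown below. What is called first, only, known or untested is meant among the compounds shown, and "the series" means these compounds.

Measured so far:
compound 1 `N/C(=N\NC(=S)N1CCOCC1)c1ccccn1` 78.8%
compound 2 `N/C(=N\NC(=S)N1CCSCC1)c1ccccn1` 81.3%
compound 3 `Cc1cccc(/C(N)=N/NC(=S)N2CCCC2)n1` 72.2%

In a functional assay on A-431 cells (Homo sapiens) for cytotoxicity, read by MTT assay, with a stated time of 72 h, tested at 30 uM (on this read-out lower numbers stand for less inhibition of growth and higher numbers for more inhibition of growth at the one concentration tested), compound 3 sits within the scatter of compound 1 and of compound 2; the three numbers show no separation. For the measured compounds named here, the only single-point step measured, a number 2.5 percentage points higher from compound 1 to compound 2 (within the scatter), concerns the group on the thiocarbonyl carbon and not the aromatic ring, so no measured step covers the change to compound 4 `N/C(=N\NC(=S)N1CCCC1)c1ccccn1`, which is hydrogen in place of methyl on an aromatic carbon. Compound 1 and compound 2 carry this unsubstituted ring and give numbers within the scatter of compound 3. The expected step is therefore a number 4.8 percentage points higher from compound 3 to compound 4 (within the scatter), none beyond the scatter. Compound 4 is estimated at 77%, expected between 65% and 88%.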

Compound 4, percent growth inhibition at one concentration: 85.2%
The estimate for compound 4 lay 8.2 percentage points below the measured number, and the stated range covers the measured number.
By their numbers in this assay, from the lowest: compounds 3, 1, 2 and 4 (each within the scatter of the next, the first and the last beyond it).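

In this assay, for the compounds shown here, hydrogen in place of methyl on the aromatic carbon next to the ring nitrogen gives the first step beyond the scatter, a number 13 percentage points higher from compound 3 to compound 4 (beyond the scatter), with pyrrolidin-1-yl on the thiocarbonyl carbon. With the unsubstituted ring, the thiocarbonyl group changes stay within the scatter, at a number 3.9 percentage points higher from compound 2 to compound 4 (within the scatter) and a number 6.4 percentage points higher from compound 1 to compound 4 (within the scatter), so they do not separate these groups. Nothing available explains the methyl step.

As far as these compounds go, whether an ethyl or methoxy group at this position would give a similar number remains open. So does whether methyl removal gives a comparable step with morpholin-4-yl or thiomorpholin-4-yl on the thiocarbonyl carbon.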